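The compounds below may be only part of what the source reports. "The series", "measured", "known", "first", "only" and "open" are said of these compounds alone.

Measured so far:
- compound 1 `COc1ccc([C@@H]2C/C(=N\O)c3c(O)cc(OCc4cn(Cc5ccccc5C)nn4)cc3O2)cc1O` gives 18000 nM
- compound 2 `COc1ccc([C@@H]2CC(=O)c3c(O)cc(OCc4cn(Cc5ccccc5F)nn4)cc3O2)cc1O` gives 7320 nM

In a functional assay on RAW264.7 cells (Mus musculus) for inhibition, read by Griess assay, with stated times of 2 h and 24 h (on this read-out lower numbers stand for stronger inhibition and higher numbers for weaker inhibition), compound 1 stands at 18000 nM as the higher of the two numbers, which makes it the weaker inhibitor of the pair, and compound 2 lies at 7320 nM on the lower side, a gap beyond the usual scatter. Among the compounds with values here, these two compounds differ in more than one place, so no measured step isolates a single change, and the series offers no direct precedent for the next comparison.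

Compound 3 `COc1ccc([C@@H]2C/C(=N\O)c3c(O)cc(OCc4cn(C5CCCC5)nn4)cc3O2)cc1O` keeps the core of compound 1 and carries cyclopentyl in place of 2-methylbenzyl on an aromatic nitrogen. Within the data shown here, with no measured step for this change, no shift beyond the scatter is expected in this assay in either direction. The expected change is a 1.2-fold lower number from compound 1 to compound 3 (0.08 log units; within the scatter) and remains a low-confidence estimate. For compound 3 the estimated value is 15000 nM with an expected range from 5000 nM to 40000 nM around it.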

Compound 3, half-maximal inhibitory concentration: 6880 nM
The estimate for compound 3 lay 2.2-fold (0.34 log units) above the measured number; low and high end bracket the measured number.
By their numbers in this assay, from the lowest: compounds 3 and 2 (each within the scatter of the next); then compound 1.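

In this assay, putting cyclopentyl in place of 2-methylbenzyl on the aromatic nitrogen of the five-membered aromatic ring gives a 2.6-fold lower number from compound 1 to compound 3 (0.42 log units; beyond the scatter), a modest step and the only measured one in the series that isolates a single change. The group on this nitrogen therefore affects the number with the rest of the molecule held fixed, and the six-membered aromatic ring of 2-methylbenzyl is not needed to reach the lower number, at least on the core of compound 1. No measurement at hand bears on the origin of this step.

The step changes heavy-atom count, ring size and aromaticity together, and the compounds shown do not separate these contributions. On these data alone, it remains open whether an open-chain butyl group, an aminoethyl chain or a carboxylic acid on the same nitrogen would move the number further in either direction, and whether the same exchange gives a comparable step on the core of compound 2.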